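Replacing the Phenyl of Compound 3 with a Thiane Ring

The source may report more compounds than this note shows. Statements on the series, on what has been measured and on what is new or still open speak of the compounds shown alone.

Compound 3 `c1ccc(CNCCCCN(C[C@H]2Cc3ccccc3CN2)[C@H]2CCCc3cccnc32)cc1` shows the lowest number of the two values shown in a functional assay on cells for antagonist activity at C-X-C chemokine receptor type 4 (Homo sapiens), read by fluorescence and calcium flux, with stated times of 25 min and 90 s; a lower number here means a stronger inhibitor, a higher number a weaker inhibitor: compound 3 gives 20.1 nM. Compound 1 `c1ccc2c(c1)CN[C@@H](CN(CCCCN(Cc1ccncc1)Cc1ccncc1)[C@H]1CCCc3cccnc31)C2` gives 832 nM in this assay, a gap from compound 3 that lies beyond the usual scatter. Compound 2 `c1ccc(CN(CCCCN(C[C@H]2Cc3ccccc3CN2)[C@H]2CCCc3cccnc32)Cc2ccccc2)cc1` reaches only a limit of this assay, recorded as > 16700 nM, so no number is known for it. For the measured compounds named here, the single measured step, an at least 830-fold lower number from compound 2 to compound 3 (2.91 log units; beyond the scatter), is large and shows that the amine nitrogen carrying one benzyl group rather than two matters greatly for potency.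

Compound 4 `c1ccc2c(c1)CN[C@@H](CN(CCCCNCC1CCSCC1)[C@H]1CCCc3cccnc31)C2` differs from compound 3 by thian-4-yl in place of phenyl on a saturated chain carbon bound to an amine nitrogen. Going by the values given here, no measured step exchanges one ring for another: the step of an at least 830-fold lower number from compound 2 to compound 3 (2.91 log units; beyond the scatter) changes how many groups sit on the nitrogen, not what kind of ring the remaining group carries, so it bears on this change only loosely. The single benzyl arrangement that served compound 3 well is kept in compound 4, with the aromatic ring turned into a saturated sulfur-containing ring of the same size. A moderate loss of potency is expected rather than a collapse. Compound 4 is expected to give 70 nM, within a range from 15 nM to 350 nM. The expected step of a 3.5-fold higher number from compound 3 to compound 4 (0.54 log units; beyond the scatter) is thus a modest weakening, likely outside the scatter but far smaller than the step seen between compound 2 and compound 3.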

Compound 4, half-maximal inhibitory concentration: 69.6 nM
For compound 4 the middle estimate is 1.0-fold (0.00 log units) above the measured one, and the stated range covers the measured number.
By their numbers in this assay, from the lowest: compound 3; then compound 4; then compound 1. At a limit, above all of these: compound 2.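

For the compounds shown here, until now, the only change measured was how many benzyl groups the amine nitrogen carries; here, the ring on the remaining group is itself exchanged. In this assay, the step of a 3.5-fold higher number from compound 3 to compound 4 (0.54 log units; beyond the scatter) is modest but beyond the scatter, so at this position on a saturated chain carbon bound to an amine nitrogen, the six-membered aromatic ring of carbon only can give way to a non-aromatic six-membered ring with a sulfur atom at some cost in potency, while inhibition remains clearly measurable. Nothing measured for these compounds explains why this exchange gives a higher number.

A single exchange alters two things at once, the loss of aromaticity and the arrival of sulfur, so the compounds shown cannot say which of them accounts for the step. A cyclohexyl group, which is non-aromatic with carbon only, would help to separate the two, while a tetrahydropyran-4-yl group with oxygen in place of sulfur, or a pyridine ring, would show how far other atoms in a ring at this position are tolerated.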